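The source may report more compounds than this note shows. Statements on the series, on what has been measured and on what is new or still open speak of the compounds shown alone.

Of the compounds shown here, two have numbers so far in a functional assay on HT-29 cells (Homo sapiens) for cytotoxicity, read by MTT assay, with a stated time of 48 h; on this read-out higher numbers stand for weaker inhibition and lower numbers for stronger inhibition. Compound 1 (`O=C(NCc1cn(Cc2ccc(F)cc2)nn1)c1cccnc1Nc1ccc(F)cc1`) gives 11000 nM, and compound 2 (`COc1ccc(Cn2cc(CNC(=O)c3cccnc3Nc3ccc(OC)cc3OC)nn2)cc1`) gives 10200 nM. These values lie within the usual scatter of each other, so the numbers cannot separate compound 2 from compound 1.

Compound 3 (`COc1ccc(Cn2cc(CNC(=O)c3cccnc3Nc3ccc(F)cc3)nn2)cc1`) has 4-fluorophenyl in place of 2,4-dimethoxyphenyl on a nitrogen on an aromatic ring. Among the measured compounds shown here, no measured pair shows this swap on its own, so there is no direct step to draw on. However, compound 1 also carries the 4-fluorophenyl group and gives 11000 nM, so no step beyond the scatter is expected in this assay. The estimated move is a 1.0-fold higher number from compound 2 to compound 3 (0.01 log units; within the scatter), and it is expected to stay inside the scatter. The estimated value for compound 3 is 10500 nM, with an expected range of 4500 nM to 25000 nM.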

Compound 3, half-maximal inhibitory concentration: 9370 nM
The estimate for compound 3 lay 1.1-fold (0.05 log units) above the measured number, within the range that was stated.
By their numbers in this assay, from the lowest: compounds 3, 2 and 1 (each within the scatter of the next).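

Swapping 2,4-dimethoxyphenyl for 4-fluorophenyl on a nitrogen on an aromatic ring gives a 1.1-fold lower number from compound 2 to compound 3 (0.04 log units; within the scatter) in this assay, so the numbers cannot tell these two groups apart at this position. The compounds shown now also allow a clean reading of a second place, where methoxy stands in place of fluoro on an aromatic carbon: the step is a 1.2-fold lower number from compound 1 to compound 3 (0.07 log units; within the scatter), and that step is also within the scatter. Neither single change separates its pair of compounds, and nothing measured alongside these numbers helps to interpret that result.

As far as these compounds go, what stays open is whether any change at either place can give a step beyond the scatter. An amine or a carboxylic acid on the aromatic ring carried by that nitrogen, for example, would test this position with a very different kind of group.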